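Swapping Trifluoromethyl for Methyl on the Sulfonamide Ring

This account rests on a few compounds, and the source may have more. Where it says the series, first, only, none or still open, it means among the compounds named here.

Measured so far:
compound 1, `O=S(=O)(NCCCCCCNCc1ccc(Br)cc1)c1ccc(C(F)(F)F)cc1`, gives 3830 nM
compound 2, `O=S(=O)(NCCCNCc1ccccc1)c1cc(C(F)(F)F)cc(C(F)(F)F)c1`, gives 11000 nM
compound 3, `COc1cccc(CNCCCNS(=O)(=O)c2cc(C(F)(F)F)cc(C(F)(F)F)c2)c1`, gives 3400 nM

These three compounds share a sulfonamide linked through a carbon chain to a benzylamine and were tested in a functional assay on MIA PaCa-2 cells (Homo sapiens) for inhibition, read by MTT assay, with a stated time of 72 h; on this read-out higher numbers stand for weaker inhibition of growth and lower numbers for stronger inhibition of growth. Compound 1 stands second highest of the three numbers: against compound 3 it lies within the scatter, while against compound 2 the gap is beyond it. For the measured compounds named here, the only single-point step among the measured compounds is a 3.2-fold lower number from compound 2 to compound 3 (0.51 log units; beyond the scatter), a change on the benzyl ring rather than on the sulfonyl ring.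

Compound 4, `Cc1ccc(S(=O)(=O)NCCCCCCNCc2ccc(Br)cc2)cc1`, differs from compound 1 in one place: methyl in place of trifluoromethyl on an aromatic carbon. Going by the values given here, no measured step touches this position or this pair of groups, so the existing data give no direct guide. In this assay the step is expected to be small, a 1.3-fold higher number from compound 1 to compound 4 (0.12 log units; within the scatter), most likely staying within the scatter. Compound 4 is therefore estimated at 5000 nM, with a range from 2000 nM to 13000 nM.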

Compound 4, concentration for 50% growth inhibition: 12300 nM
For compound 4 the middle estimate is 2.5-fold (0.39 log units) below the measured one; low and high end bracket the measured number.
By their numbers in this assay, from the lowest: compounds 3 and 1 (each within the scatter of the next); then compounds 2 and 4 (each within the scatter of the next).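

In this assay, for the compounds shown here, the move from trifluoromethyl to methyl gives a 3.2-fold higher number from compound 1 to compound 4 (0.51 log units; beyond the scatter) and provides the first direct reading at this aromatic carbon, para to a large group. It shows that the group at this place affects growth inhibition of these cells, something the earlier step, made elsewhere in the molecule, could not show. In this pair, trifluoromethyl goes with the stronger inhibition of growth, but nothing measured here explains why the two groups differ.

From the compounds shown here alone, only these two groups can be compared at this place, so it remains open how a chlorine atom, a nitrile or plain hydrogen would behave there. Going by these compounds, it is also open whether the same swap would produce a step of similar size on the shorter chain of compound 2 and compound 3.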